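Trifluoromethyl Step Carried Onto a Tosylated Core

A few compounds are considered here, and "the series" means these few. Any claim that something is new, unique, unknown or untested is made for them only; others in the source may bear on it.

Compound 1 `C=C1C[C@]23C[C@@]1(O)CC[C@H]2c1ccc(O)c(C)c1[C@@H]3Cn1cc(-c2ccc(C(F)(F)F)cc2)nn1` carries a 4-(trifluoromethyl)phenyl group on its triazole and a free hydroxy on the aromatic ring of the shared core. In a functional assay on HL-60 cells (Homo sapiens) for cytotoxicity, read by MTT assay, with a stated time of 4 days (on this read-out lower numbers stand for stronger inhibition and higher numbers for weaker inhibition), compound 1 gives 8950 nM. Compound 2 `C=C1C[C@]23C[C@@]1(O)CC[C@H]2c1ccc(O)c(C)c1[C@@H]3Cn1cc(-c2ccccc2)nn1` keeps that core but bears a plain phenyl. In this assay compound 2 reaches only > 20000 nM, which is a limit of the assay rather than a number. The change trifluoromethyl in place of hydrogen on an aromatic carbon thus gives an at least 2.2-fold lower number from compound 2 to compound 1 (0.34 log units; beyond the scatter), and because two of the three values sit at the limit of > 20000 nM in this assay, at which 2 of the 3 values shown sit, the upper end of that step cannot be read.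

Compound 3 `C=C1C[C@]23C[C@@]1(O)CC[C@H]2c1ccc(OS(=O)(=O)c2ccc(C)cc2)c(C)c1[C@@H]3Cn1cc(-c2ccccc2)nn1` differs from compound 2 by (4-methylphenyl)sulfonyl in place of hydrogen on an oxygen on an aromatic ring; this is how its core differs from the cores of compound 1 and compound 2. In this assay compound 3 sits at the limit of > 20000 nM. Accordingly a step that the two limits leave unreadable from compound 2 to compound 3.

Compound 4 `C=C1C[C@]23C[C@@]1(O)CC[C@H]2c1ccc(OS(=O)(=O)c2ccc(C)cc2)c(C)c1[C@@H]3Cn1cc(-c2ccc(C(F)(F)F)cc2)nn1` is compound 3 carrying (trifluoromethyl in place of hydrogen on an aromatic carbon), the same change as before, at the same place. The step from compound 3 to compound 4 is expected to be an at least 1.6-fold lower number from compound 3 to compound 4 (0.22 log units; that floor lies within the scatter). That expectation rests on compound 2 and compound 1, whose step is an at least 2.2-fold lower number from compound 2 to compound 1 (0.34 log units; beyond the scatter). Compound 4 is expected at 12000 nM, between 5000 nM and 30000 nM. Since compound 3 shows only a limit, a limit for compound 4 remains quite possible.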

Compound 4, half-maximal inhibitory concentration: > 20000 nM
Compound 4 ended at the assay's limit; the forecaster's own chance of this, stated with the estimate: 40%; at least 1.6-fold (0.22 log units) between middle value and limit.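

In this assay compound 4 gives > 20000 nM, which is a limit of the assay and not a number. Because compound 3 and compound 4 both rest at a limit, the step between them cannot be read, so the lower number that trifluoromethyl gave on the free-hydroxy core is neither confirmed nor refuted on the tosylated core: the limit of > 20000 nM in this assay, at which 3 of the 4 values shown sit.

Among these compounds, the one step that can be read is the (4-methylphenyl)sulfonyl change with the 4-(trifluoromethyl)phenyl group in place, an at least 2.2-fold higher number from compound 1 to compound 4 (0.34 log units; beyond the scatter), and this single pair shows that the free hydroxy goes with the stronger reading.

On these data alone, whether a methyl or an acetyl group on that oxygen would keep the reading of compound 1 stays open. As far as these compounds go, it is also open whether an amine or a carboxylic acid in the place of the trifluoromethyl would give a number clear of the limit on either core.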